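This account rests on a few compounds, and the source may have more. Where it says the series, first, only, none or still open, it means among the compounds named here.

Working notes on the series. In a functional assay on MCF7 cells (Homo sapiens) for antiproliferative activity, read by MTT assay, with a stated time of 48 h (on this read-out higher numbers stand for weaker inhibition and lower numbers for stronger inhibition), compound 1 (`COc1ccc(C(=O)c2ccc3c(c2)C=CC(C)(C)O3)c(NC(=O)CBr)c1`) gives 2880 nM and compound 2 (`C=C(c1cc(OC)c(OC)c(OC)c1)c1ccc(OC)cc1NC(=O)CO`) gives 110 nM as the lower of the two numbers, and the gap between them lies beyond the scatter. Compound 3 (`C=C(c1cc(OC)c(OC)c(OC)c1)c1ccc(OC)cc1NC(=O)CN(C)C`) differs from compound 2 in one place (dimethylamino in place of hydroxy on a saturated chain carbon bound to a carbonyl carbon). For the measured compounds named here, no measured pair shows this change, so the expectation rests on compound 2 alone. In this assay the estimated 1.8-fold higher number from compound 2 to compound 3 (0.26 log units; within the scatter) is expected to be small, toward weaker inhibition, and perhaps not beyond the scatter. For compound 3 the expected value is 200 nM (estimated range 40 nM to 900 nM).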

Compound 3, half-maximal inhibitory concentration: 390 nM
For compound 3 the middle estimate is 2.0-fold (0.29 log units) below the measured one; low and high end bracket the measured number.
By their numbers in this assay, from the lowest: compound 2; then compound 3; then compound 1.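

Placing dimethylamino in place of hydroxy on a saturated chain carbon bound to a carbonyl carbon gives a 3.5-fold higher number from compound 2 to compound 3 (0.55 log units; beyond the scatter), toward weaker inhibition in this assay. This position therefore responds to the group it carries, though the step is modest, and the change swaps hydroxy for a larger group and removes a hydrogen-bond donor at once, so these two differences cannot be separated here. Nothing shown gives a reason for the step.

Open, going by these compounds, is how a methoxy group, a primary amine or a carboxylic acid would read at this place. Also open, on these data alone, is whether dimethylamino on a longer chain gives a similar step.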